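This account rests on a few compounds, and the source may have more. Where it says the series, first, only, none or still open, it means among the compounds named here.

Working notes on the series. Of the compounds shown here, three have been measured in a functional assay on M14 cells (Homo sapiens) for cytotoxicity, read by sulforhodamine B assay, with a stated time of 48 h; on this read-out lower numbers stand for stronger inhibition of growth and higher numbers for weaker inhibition of growth. Compound 1 `ClCc1ccc(Cn2cnc3c(Cl)ncnc32)cc1` gives 3460 nM in this assay and stands second highest of the three numbers. Its nearest neighbour is compound 3 `ClCc1cccc(Cn2cnc3nc(Cl)nc(Cl)c32)c1`, which gives 2630 nM in this assay, a gap within the scatter, so the two cannot be ordered. The furthest is compound 2 `Nc1nc(Cl)c2ncn(Cc3ccccc3CCl)c2n1`, which gives 39800 nM in this assay, a gap beyond the scatter. No two of these compounds differ in a single place, so no measured step is available.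

The next compound is compound 4 `ClCc1ccc(Cn2cnc3c(Cl)nc(Cl)nc32)cc1`, not yet measured in this assay. It differs from compound 1 by chloro in place of hydrogen on an aromatic carbon. Compound 3 also carries two chloro groups on the shared core and its value, 2630 nM, sits within the scatter of the value of compound 1, so no change beyond the scatter is expected from this step. The step from compound 1 to compound 4 is estimated at a 1.3-fold lower number from compound 1 to compound 4 (0.11 log units; within the scatter). Compound 4 is expected to give 2700 nM in this assay, with a range from 1200 nM to 6000 nM.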

Compound 4, concentration for total growth inhibition: 24000 nM
For compound 4 the middle estimate is 8.9-fold (0.95 log units) below the measured one; measured number outside the range, above it.
By their numbers in this assay, from the lowest: compounds 3 and 1 (each within the scatter of the next); then compounds 4 and 2 (each within the scatter of the next).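

For the compounds shown here, this is the first measured step, and it shows that the place between two ring nitrogen atoms is not indifferent to substitution in this assay. Chloro in place of hydrogen there gives a 6.9-fold higher number from compound 1 to compound 4 (0.84 log units; beyond the scatter) and so weaker inhibition of growth, a change beyond the scatter that the earlier compounds could not show. Nothing shown here bears on the reason for this step.

On these data alone, the step rests on a single pair, so it remains open whether fluoro, methyl or methoxy at this same place would move the number as chloro does. Also open, as far as these compounds go, is whether the step would keep its size with the chloromethyl group placed elsewhere in the molecule.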